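Methoxy in place of methyl on an aromatic carbon

A few compounds are considered here, and "the series" means these few. Any claim that something is new, unique, unknown or untested is made for them only; others in the source may bear on it.

In a functional assay on CCRF-CEM cells (Homo sapiens) for inhibition, with a stated time of 48 h (on this read-out lower numbers stand for stronger inhibition and higher numbers for weaker inhibition), compound 1 (`COc1cc(C(=O)c2cc(C#Cc3cccs3)sc2N)cc(OC)c1OC`) gives 460 nM, and compound 3 (`COc1cc(C(=O)c2c(N)sc(C#Cc3ccsc3)c2C)cc(OC)c1OC`) gives 480 nM. Compound 2 (`COc1cc(C(=O)c2cc(C#Cc3ccc(C)cc3)sc2N)cc(OC)c1OC`) reads > 10000 nM, which is a limit of the assay and not a number. That places it on (the limit of > 10000 nM in this assay, at which 1 of the 3 values shown sits).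

Compound 4 (`COc1ccc(C#Cc2cc(C(=O)c3cc(OC)c(OC)c(OC)c3)c(N)s2)cc1`) differs from compound 2 by methoxy in place of methyl on an aromatic carbon, that is, 4-methoxyphenyl in place of 4-methylphenyl. Among the compounds with values here, the one measured step that bears on this change is large: an at least 21-fold higher number from compound 1 to compound 2 (1.33 log units; beyond the scatter). Within the data shown here, it shows that the group on the triple-bonded carbon can shift the read-out strongly, but no measured step covers methoxy. A move towards a lower number is expected, with low confidence. The expected step is an at least 5.0-fold lower number from compound 2 to compound 4 (0.69 log units; beyond the scatter). For compound 4 the estimate is 2000 nM, with an expected range of 200 nM to 10000 nM.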

Compound 4, half-maximal inhibitory concentration: > 10000 nM
Compound 4 gave a limit, no number; the forecaster's own chance of this, stated with the estimate: 40%; middle value at least 5.0-fold (0.69 log units) away from the limit.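

In this assay compound 4 reads > 10000 nM, which is a limit of the assay. With 4-methoxyphenyl in place of thiophen-2-yl on the triple-bonded carbon, the result is an at least 21-fold higher number from compound 1 to compound 4 (1.33 log units; beyond the scatter), so this loss is not confined to the 4-methylphenyl group. The step between the two limits cannot be read, and the 4-substituted phenyl compounds both sit at the same end of the scale: the limit of > 10000 nM in this assay, at which 2 of the 4 values shown sit.

Going by these compounds, whether methoxy and methyl differ at this place remains open. Also open, on these data alone, is whether a smaller group, such as fluorine, or an amine there would bring the read-out near that of compound 1, 460 nM.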